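The compounds below may be only part of what the source reports. "The series", "measured", "known", "first", "only" and "open" are said of these compounds alone.

Going by the values given here, in an ADME assay on Vero cells (Chlorocebus sabaeus) for cytotoxicity, read by neutral red uptake, with a stated time of 48 h (on this read-out lower numbers stand for stronger inhibition and higher numbers for weaker inhibition), compound 1 (`Cc1cc(NCCCCCCNc2ccnc3cc(Cl)ccc23)nc(N2CCN(C)CC2)n1`) gives 10400 nM, the lower of the two numbers measured so far. Compound 2 (`Cc1cc(Cl)nc(NCCNc2ccnc3cc(Cl)ccc23)n1`) gives 43000 nM, a gap beyond the usual scatter, but it differs from compound 1 in more than one place. Compound 3 (`Cc1cc(NCCCCCCNc2ccnc3cc(Cl)ccc23)nc(N2CCCCC2)n1`) has piperidin-1-yl in place of the 4-methylpiperazin-1-yl of compound 1, on an aromatic carbon between two ring nitrogen atoms: piperidin-1-yl in place of 4-methylpiperazin-1-yl on an aromatic carbon. Among the compounds with values here, no measured pair shows a change of this kind, so the expectation is anchored only on compound 1 at 10400 nM. A modest move toward a lower number in this assay is expected, about the size of the usual scatter. The estimated change is a 1.9-fold lower number from compound 1 to compound 3 (0.28 log units; within the scatter). For compound 3 the estimated value is 5500 nM, with an expected range from 2300 nM to 13000 nM.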

Compound 3, half-maximal inhibitory concentration: 8800 nM
Compound 3: the middle estimate sits 1.6-fold (0.20 log units) below what was measured; the measured number falls inside the stated range.
By their numbers in this assay, from the lowest: compounds 3 and 1 (each within the scatter of the next); then compound 2.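

In this assay the change on the aromatic carbon between two ring nitrogen atoms, from 4-methylpiperazin-1-yl to piperidin-1-yl, gives a 1.2-fold lower number from compound 1 to compound 3 (0.07 log units; within the scatter) and is the only comparison shown that isolates a single place. At this position, then, a six-membered non-aromatic ring with 1 hetero atom and one with 2 hetero atoms cannot be told apart on this read-out, so the second ring nitrogen of the leaving group makes no difference that can be read here. Nothing at hand bears on why the two values stay this close.

On these data alone, whether morpholin-4-yl, a dimethylamino group or a primary amine on this same carbon would also stay within the scatter of compound 1 remains open. As far as these compounds go, it is equally open whether a longer chain in compound 1 would shift the number in this assay at all.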